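A new group at the assay limit

The source may report more compounds than this note shows. Statements on the series, on what has been measured and on what is new or still open speak of the compounds shown alone.

- compound 1 `C/C(=C\CC/C(C)=C/CC[C@@H]1[C@@]2(C)CCC(=O)C(C)(C)[C@H]2CC[C@@]1(C)O)CC/C=C(\C)C(=O)OCc1cn(-c2ccccc2C(F)(F)F)nn1`: > 150000 nM
- compound 2 `C/C(=C\CC/C(C)=C/CC[C@@H]1[C@@]2(C)CCC(=O)C(C)(C)[C@H]2CC[C@@]1(C)O)CC/C=C(\C)C(=O)OCc1cn(-c2ccccc2C)nn1`: > 150000 nM

Both values come from a functional assay on MDA-MB-231 cells (Homo sapiens) for antiproliferative activity, read by MTT assay, with a stated time of 48 h (on this read-out higher numbers stand for weaker inhibition and lower numbers for stronger inhibition), and both are limits, not numbers. Compound 2 stands at > 150000 nM, which is a limit. Compound 3 `COc1ccc(-n2cc(COC(=O)/C(C)=C/CC/C(C)=C/CC/C(C)=C/CC[C@@H]3[C@@]4(C)CCC(=O)C(C)(C)[C@H]4CC[C@@]3(C)O)nn2)cc1` carries one change: 4-methoxyphenyl in place of 2-methylphenyl on an aromatic nitrogen. Within the data shown here, the one measured step, a step that the two limits leave unreadable from compound 1 to compound 2, concerns a different swap on the same aromatic group and gives no size. The evidence amounts to the limit of > 150000 nM in this assay, at which 2 of the 2 values shown sit. No clear shift in either direction is therefore expected in this assay, and another limit is likely. The expected step is a number no higher from compound 2 to compound 3 (the limit leaves the size open). Compound 3 is estimated at 150000 nM, with an expected range of 60000 nM to 300000 nM.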

Compound 3, half-maximal inhibitory concentration: > 150000 nM
Compound 3 ended at the assay's limit; the forecaster's own chance of this, stated with the estimate: 70%; the middle value sits exactly at the limit.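

Among these compounds, compound 1, compound 2 and compound 3 all sit at the assay's limit, so no step between them can be read. The compounds shown leave open whether any aromatic group at this place would give a measurable value.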